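Hydroxycarbamoyl to (2-aminophenyl)carbamoyl on compound 1

The source may report more compounds than this note shows. Statements on the series, on what has been measured and on what is new or still open speak of the compounds shown alone.

In a functional assay on MC-38 cells (Mus musculus) for antiproliferative activity, read by CCK-8 assay, with a stated time of 72 h (a lower number here means a stronger inhibitor of growth, a higher number a weaker inhibitor of growth), compound 1 `Nc1nc(NCc2ccc(C(=O)NO)cc2)nc2nc(-c3ccco3)nn12` stands without a number: "not determined" (no result reported). Among the measured compounds shown here, two relatives on the shared core give the only guide. Compound 2 `Nc1nc(NCCOc2ccc(C(=O)NO)cc2)nc2nc(-c3ccco3)nn12` reaches only a limit of the assay, > 100000 nM. Compound 3 `Nc1nc(NCCCCCCC(=O)NO)nc2nc(-c3ccco3)nn12` gives 35700 nM. The compound to be measured next is compound 4 `Nc1ccccc1NC(=O)c1ccc(CNc2nc(N)n3nc(-c4ccco4)nc3n2)cc1`. The change is 2-aminophenyl in place of hydroxy on an amide-type nitrogen. No measured step sizes this change, and compound 1 offers no starting value. In this assay the expectation is therefore no move beyond the scatter, in either direction, from the weak level of compound 3 at 35700 nM. For compound 4 the estimated value is 30000 nM, with an expected range from 6000 nM to 100000 nM.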

Compound 4, concentration for 50% growth inhibition: 14100 nM
For compound 4 the middle estimate is 2.1-fold (0.33 log units) above the measured one, within the range that was stated.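

In this assay, among the compounds shown here, the entry for compound 1 is "not determined" (no result reported) and no step to compound 4 can be read. Left open is what 2-aminophenyl in place of hydroxy does on the shared core. Nothing shown bears on the result for compound 4.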